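From Propanoyl to Methyl on a Shared Core

This account rests on a few compounds, and the source may have more. Where it says the series, first, only, none or still open, it means among the compounds named here.

Among the compounds with values here, in a functional assay on HL-60 cells (Homo sapiens) for inhibition, read by MTT assay, with a stated time of 72 h (a higher number here means a weaker inhibitor, a lower number a stronger inhibitor), compound 1 `CCC(=O)N1CCN(c2nnc3nncn3n2)CC1` gives 10100 nM, the only actual number available so far. Compound 2 `OCC(CO)(CO)Nc1nnc2nncn2n1` returns only a limit, > 100000 nM, and so gives no number to set beside it. The next compound to be measured is compound 3 `CN1CCN(c2nnc3nncn3n2)CC1`, which keeps the core of compound 1 but carries methyl in place of propanoyl on an amine nitrogen in a ring. Within the data shown here, no measured pair shows what such a change does in this assay, so any forecast remains loose. A modest weakening is expected, with a result within the usual scatter quite possible. The expected change is a 2.0-fold higher number from compound 1 to compound 3 (0.30 log units; within the scatter). For compound 3 the estimated value is 20000 nM, with an expected range from 6000 nM to 80000 nM.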

Compound 3, half-maximal inhibitory concentration: 8540 nM
Estimate against measurement, compound 3: 2.3-fold (0.37 log units) above; measured number inside the range.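

In this assay, within the data shown here, the first measured step at this position, on an amine nitrogen in a ring, is a 1.2-fold lower number from compound 1 to compound 3 (0.07 log units; within the scatter). Propanoyl, with its carbonyl and 4 heavy atoms, gives way to methyl, with 1 heavy atom, and the two compounds do not separate beyond the scatter, so within this pair the carbonyl is not required to hold the value. Nothing measured here gives a reason for this result.

As far as these compounds go, it remains open whether a larger group on this nitrogen, such as benzoyl or a longer chain ending in a carboxylic acid, would move the number beyond the scatter. Compound 2 gives > 100000 nM, a limit and not a number, and it differs from compound 1 in more than one place, so it does not settle this question.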